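A few compounds are considered here, and "the series" means these few. Any claim that something is new, unique, unknown or untested is made for them only; others in the source may bear on it.

Compound 1 `O=C1OC[C@H](Cc2ccccc2)[C@H]1Cc1ccc(Cl)c(Cl)c1` gives 26000 nM
Compound 2 `O=C1OC[C@H](Cc2ccc(O)cc2)[C@H]1Cc1ccc(Cl)c(Cl)c1` gives "not determined" (no result reported)
Compound 3 `Cc1ccc(C[C@H]2COC(=O)[C@@H]2Cc2ccc(Cl)c(Cl)c2)cc1` gives "not determined" (no result reported)

In a functional assay on HeLa cells (Homo sapiens) for cytotoxicity, read by WST assay, with a stated time of 48 h (on this read-out higher numbers stand for an effect only at larger amounts of compound and lower numbers for an effect already at smaller amounts), compound 3 reads "not determined" (no result reported) and so has no single number, as is also the case for compound 2. Compound 4 `O=C1OC[C@H](Cc2ccc(F)cc2)[C@H]1Cc1ccc(Cl)c(Cl)c1` is still unmeasured. The structural change is fluoro in place of methyl on an aromatic carbon, para to a large group. Going by the values given here, no measured step sizes this change. Among the compounds with values here, the only number available is compound 1 at 26000 nM, so a result in that region is expected, with no step beyond the usual scatter in this assay and no direction favoured. For compound 4 the estimated value is 22000 nM, with an expected range of 8000 nM to 60000 nM.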

Compound 4, half-maximal effective concentration: 19000 nM
For compound 4 the middle estimate is 1.2-fold (0.06 log units) above the measured one; the range from low to high includes it.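

In this assay, going by these compounds alone, adding fluoro para to a large group gives a 1.4-fold lower number from compound 1 to compound 4 (0.14 log units; within the scatter), the only step at this position that can be sized; the steps involving compound 2 and compound 3 cannot be read. This position therefore accepts fluoro without a step beyond the scatter. No measured evidence bears on this result. On these data alone, it remains open whether an amine, a carboxylic acid or a longer chain at this position would give a step beyond the scatter.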